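From benzyl to 4-chlorobenzyl

A few compounds are considered here, and "the series" means these few. Any claim that something is new, unique, unknown or untested is made for them only; others in the source may bear on it.

In an ADME assay on HEK-293T cells (Homo sapiens) for inhibition, read by CCK-8 assay, with a stated time of 48 h, tested at 20 uM (a higher number here means more inhibition of growth at the concentration tested, a lower number less inhibition of growth), compound 1 (`Cc1ccc(S(=O)(=O)Oc2ccccc2/C=C(\C#N)C(=O)Nc2nnc(Cc3ccccc3)s2)cc1`) gives 15%, compound 2 (`COc1ccc(S(=O)(=O)Oc2ccccc2/C=C(\C#N)C(=O)Nc2nnc(Cc3ccccc3)s2)cc1`) gives 23% and compound 3 (`N#C/C(=C\c1ccccc1OS(=O)(=O)c1ccc(Cl)cc1)C(=O)Nc1nnc(Cc2ccccc2)s1`) gives 25%. Compound 2 thus lies within the scatter of both other compounds. Compound 4 (`COc1ccc(S(=O)(=O)Oc2ccccc2/C=C(\C#N)C(=O)Nc2nnc(Cc3ccc(Cl)cc3)s2)cc1`) differs from compound 2 by chloro in place of hydrogen on an aromatic carbon, turning benzyl into 4-chlorobenzyl. Going by the values given here, no measured step makes this exact change. The closest evidence is chloro entering elsewhere in the molecule, replacing other groups, with a number 10 percentage points higher from compound 1 to compound 3 (within the scatter) and a number 2 percentage points higher from compound 2 to compound 3 (within the scatter). A change beyond the scatter is therefore not expected, and the expected step is a number 4 percentage points higher from compound 2 to compound 4 (within the scatter). Compound 4 is estimated at 27%, with an expected range of 14% to 42%.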

Compound 4, percent growth inhibition at one concentration: 26%
Compound 4: middle estimate off by 1 percentage points, on the high side; the range from low to high includes it.
By their numbers in this assay, from the lowest: compounds 1, 2, 3 and 4 (each within the scatter of the next, the first and the last beyond it).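

Going by these compounds alone, compound 4 gives the first reading of a change at the benzyl end, where the earlier compounds differed only in the methyl, methoxy or chloro group elsewhere in the molecule. In this assay, turning benzyl into 4-chlorobenzyl gives a number 3 percentage points higher from compound 2 to compound 4 (within the scatter), so this chloro, para to a large group, brings no change beyond the scatter. No measurement offered here explains this result. The compounds shown leave open whether an amine or a carboxylic acid in place of this chloro would give a step beyond the scatter.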